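Urea to Amide Swap on a Pyrazole Series

A few compounds are considered here, and "the series" means these few. Any claim that something is new, unique, unknown or untested is made for them only; others in the source may bear on it.

Measured compounds:
Compound 1 `O=C(Nc1cccc(-n2cc(-c3ccncc3)c(-c3cc(O)cc(Cl)c3)n2)c1)Nc1ccc(Cl)c(Cl)c1` — 62%
Compound 2 `COc1cc(Cl)cc(-c2nn(-c3cccc(NC(=O)Nc4ccc(Cl)c(Cl)c4)c3)cc2-c2ccncc2)c1` — 68%

In a functional assay on SR cells (Homo sapiens) for inhibition, read by sulforhodamine B assay, with a stated time of 48 h, tested at 1 uM (on this read-out lower numbers stand for a stronger effect and higher numbers for a weaker effect at the one concentration tested), compound 1 gives 62% and compound 2 gives 68%. Compound 2 carries the higher of the two numbers, yet a number 6 percentage points higher from compound 1 to compound 2 (within the scatter), so the two compounds cannot be told apart on this read-out.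

Compound 3 `COc1cc(Cl)cc(-c2nn(-c3cccc(NC(=O)c4cccc(C(F)(F)F)c4)c3)cc2-c2ccncc2)c1` is not yet measured. It differs from compound 2 in one place: 3-(trifluoromethyl)phenyl in place of (3,4-dichlorophenyl)amino on a carbonyl carbon. Among the compounds with values here, no measured step touches this part of the molecule; the only step available, from compound 1 to compound 2, concerns a methyl on an oxygen elsewhere and says nothing about replacing (3,4-dichlorophenyl)amino with 3-(trifluoromethyl)phenyl on the carbonyl carbon. Without a comparable step, the expectation for compound 3 rests on compound 2 alone, with a wide range. Compound 3 is estimated at 70%, between 45% and 95%, a step of a number 2 percentage points higher from compound 2 to compound 3 (within the scatter) that is expected to lie within the scatter.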

Compound 3, a percentage reported as activity, at one concentration (the size of the read-out at that concentration, not a potency): 58%
Beside the measured number, compound 3's estimate is 12 percentage points above it, and the stated range covers the measured number.
By their numbers in this assay, from the lowest: compounds 3, 1 and 2 (each within the scatter of the next).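

In this assay, within the data shown here, 3-(trifluoromethyl)phenyl in place of (3,4-dichlorophenyl)amino on the carbonyl carbon gives a number 10 percentage points lower from compound 2 to compound 3 (within the scatter), the first reading at this position, since the earlier step concerned only a methyl on an oxygen elsewhere. The swap turns the urea into an amide, removing the amino nitrogen with its hydrogen-bond donor and both chlorines, yet this read-out does not separate the two compounds, so none of these features is shown to matter here at the one concentration tested. Nothing available explains this outcome.

The step changes the linking nitrogen and the ring substituents together, so their separate contributions remain unresolved. On these data alone, it also remains open how a piperidine or a carboxylic acid on the carbonyl side would read out.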